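Benzyl-linked chloropurines: second chloro on the meta series

A few compounds are considered here, and "the series" means these few. Any claim that something is new, unique, unknown or untested is made for them only; others in the source may bear on it.

Four compounds share a chloromethyl-substituted benzyl group on a chlorinated purine. Compound 1 `ClCc1ccc(Cn2cnc3c(Cl)ncnc32)cc1` and compound 2 `ClCc1cccc(Cn2cnc3ncnc(Cl)c32)c1` carry one chloro on the core; compound 3 `ClCc1ccc(Cn2cnc3c(Cl)nc(Cl)nc32)cc1` and compound 4 `ClCc1cccc(Cn2cnc3nc(Cl)nc(Cl)c32)c1` carry two. The difference between the cores of compound 1 and compound 2 is not broken down here.

In a functional assay on M14 cells (Homo sapiens) for cytotoxicity, read by sulforhodamine B assay, with a stated time of 48 h (a lower number here means that less compound is tolerated, a higher number that more compound is tolerated), compound 1 gives 9120 nM. Compound 3 gives 53700 nM in this assay, and compound 2 gives 67600 nM. The values of compound 2 and compound 3 lie within the scatter of each other.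

One change is made twice. From compound 1 to compound 3 it is chloro in place of hydrogen on an aromatic carbon, and the step is a 5.9-fold higher number from compound 1 to compound 3 (0.77 log units; beyond the scatter). From compound 2 to compound 4 it is chloro in place of hydrogen on an aromatic carbon, the same change at the same place, this time on the core of compound 2.

Compound 4 is not yet measured in this assay. Resting on the single measured case, the step from compound 2 to compound 4 is expected to be a 3.7-fold higher number from compound 2 to compound 4 (0.57 log units; beyond the scatter), because a 5.9-fold higher number from compound 1 to compound 3 (0.77 log units; beyond the scatter) points that way. Compound 4 is therefore estimated to give 250000 nM in this assay, from 100000 nM to 600000 nM.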

Compound 4, concentration lethal to 50% of the cells: 5120 nM
Estimate against measurement, compound 4: 49-fold (1.69 log units) above, outside the stated range (below it).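

In this assay, chloro in place of hydrogen on an aromatic carbon, between two ring nitrogen atoms, gives a 13-fold lower number from compound 2 to compound 4 (1.12 log units; beyond the scatter), which runs against the direction seen on the core of compound 1. In this series the change therefore does not carry from one core to the other, in either direction or size: the same change on two cores in this assay, a 5.9-fold higher number (0.77 log units; beyond the scatter) from compound 1 to compound 3 and a 13-fold lower number (1.12 log units; beyond the scatter) from compound 2 to compound 4, 78-fold (1.89 log units) apart, beyond the scatter of two such steps This rests on a single pair per core, so it shows that the step depends on the core within these four compounds, but not which feature of the cores governs it, nor how the change would behave on any further core.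

Still open, from the compounds shown here alone, is whether another group at the same place, such as an amine or a methoxy group, would also give steps that differ between the two cores. Also open, going by these compounds, is what a hydroxymethyl group in place of the chloromethyl group would do to either step.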